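Compound 2 and a sulfonyl addition

The source may hold more compounds than are shown below. What is called first, only, known or untested is meant among the compounds shown, and "the series" means these compounds.

In an ADME assay on L02 cells (Homo sapiens) for cytotoxicity, read by MTT assay, with a stated time of 24 h (on this read-out higher numbers stand for weaker inhibition and lower numbers for stronger inhibition), compound 2 (`O=C1/C(=C/c2ccncc2)CNC/C1=C\c1ccccc1C(F)(F)F`) gives 13400 nM. Compound 1 (`O=C1/C(=C/c2cccnc2)CN(S(=O)(=O)c2ccc([N+](=O)[O-])cc2)C/C1=C\c1ccccc1C(F)(F)F`) gives 15700 nM, and these two numbers lie within the scatter of each other. Compound 3 (`O=C1/C(=C/c2ccncc2)CN(S(=O)(=O)c2ccc([N+](=O)[O-])cc2)C/C1=C\c1ccccc1C(F)(F)F`) has (4-nitrophenyl)sulfonyl in place of hydrogen on an amine nitrogen in a ring of compound 2: (4-nitrophenyl)sulfonyl in place of hydrogen on an amine nitrogen in a ring. Going by the values given here, no measured pair isolates this change. Compound 1 carries the same group and gives 15700 nM, so no step beyond the scatter is expected in this assay. The expected change is a 1.0-fold higher number from compound 2 to compound 3 (0.02 log units; within the scatter). Compound 3 is estimated at 14000 nM, within a range of 6000 nM to 32000 nM.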

Compound 3, half-maximal inhibitory concentration: 18600 nM
The estimate for compound 3 lay 1.3-fold (0.12 log units) below the measured number; the range from low to high includes it.
By their numbers in this assay, from the lowest: compounds 2, 1 and 3 (each within the scatter of the next).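

In this assay the (4-nitrophenyl)sulfonyl group on the amine nitrogen in the ring now has a measured pair of its own, with a 1.4-fold higher number from compound 2 to compound 3 (0.14 log units; within the scatter) as the whole of the step. Pyridin-4-yl in place of pyridin-3-yl, with that sulfonyl group present, gives a 1.2-fold higher number from compound 1 to compound 3 (0.07 log units; within the scatter) as its step, so neither single change separates these compounds. Nothing available speaks to why these steps are so small. As far as these compounds go, whether a methyl or an acetyl group on that same nitrogen would move the number beyond the scatter remains open.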